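Removing the Chloro Group From Compound 2

This account rests on a few compounds, and the source may have more. Where it says the series, first, only, none or still open, it means among the compounds named here.

Compound 2 `COc1ccc(OC)c(/C=C/C(=O)N/N=C/c2ccc(Cl)cc2)c1` was tested in a functional assay on UO-31 cells (Homo sapiens) for antiproliferative activity, read by sulforhodamine B assay, with a stated time of 48 h (a lower number here means a stronger inhibitor of growth, a higher number a weaker inhibitor of growth), where compound 2 gives > 100000 nM, a limit of the assay rather than a measured number. This is the limit described by the limit of > 100000 nM in this assay, at which 1 of the 2 values shown sits. Compound 1 `COc1ccc(OC)c(/C=C/c2nnc(Nc3ccc(Cl)cc3)o2)c1`, a different member of the same set, gives 12600 nM in this assay. Compound 3 `COc1ccc(OC)c(/C=C/C(=O)N/N=C/c2ccccc2)c1` differs from compound 2 by hydrogen in place of chloro on an aromatic carbon. Among the compounds with values here, with no measured step of this kind, the expected step is a number no higher from compound 2 to compound 3 (the limit leaves the size open), nothing beyond the scatter. Compound 3 is therefore estimated at 100000 nM, within 30000 nM to 300000 nM, most likely again reported only as a limit.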

Compound 3, concentration for total growth inhibition: 85500 nM
Compound 3: middle estimate off by 1.2-fold (0.07 log units), on the high side, within the range that was stated.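

Replacing chloro with hydrogen gives an actual number rather than a limit in this assay, with an at least 1.1-fold lower number from compound 2 to compound 3 (0.06 log units; that floor lies within the scatter). The change from 4-chlorophenyl to phenyl at this position therefore shows no loss of growth inhibition, but no gain beyond the scatter can be claimed either. Compound 2 stands at a limit of the assay, which leaves the true size of the step open: the limit of > 100000 nM in this assay, at which 1 of the 3 values shown sits. Whether an amine or a carboxylic acid in the same place would shift the number remains an open question.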